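A few compounds are considered here, and "the series" means these few. Any claim that something is new, unique, unknown or untested is made for them only; others in the source may bear on it.

In a functional assay on MCF7 cells (Homo sapiens) for cytotoxicity, read by MTT assay, with a stated time of 48 h (a higher number here means a weaker inhibitor, a lower number a stronger inhibitor), compound 1 `Cc1ncc([N+](=O)[O-])n1CCSc1nnc(-c2ccccc2)o1` gives 20500 nM and compound 2 `Cc1ncc([N+](=O)[O-])n1CCSc1nnc(-c2ccccc2N)o1` gives 20100 nM as its value, while compound 3 `Cc1ncc([N+](=O)[O-])n1CCSc1nnc(-c2ccc(F)cc2)o1` gives 8100 nM as the lowest of the three numbers. Compound 4 `Cc1ncc([N+](=O)[O-])n1CCSc1nnc(-c2ccc(Cl)cc2)o1` differs from compound 3 by a single exchange, chloro in place of fluoro on an aromatic carbon, para to a large group (chloro in place of fluoro on an aromatic carbon). The closest evidence is the modest fluoro step (a 2.5-fold lower number from compound 1 to compound 3 (0.40 log units; beyond the scatter)), whereas the amino step (a 1.0-fold lower number from compound 1 to compound 2 (0.01 log units; within the scatter)) stayed within the scatter. Within the data shown here, no measured pair exchanges fluoro for chloro, so no step beyond the scatter is expected in this assay and the estimated step is small (a 1.1-fold lower number from compound 3 to compound 4 (0.03 log units; within the scatter)). Compound 4 is expected near 7500 nM (estimated range 3500 nM to 16000 nM).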

Compound 4, half-maximal inhibitory concentration: 18700 nM
The estimate for compound 4 lay 2.5-fold (0.40 log units) below the measured number, and the stated range ends below it.
By their numbers in this assay, from the lowest: compound 3; then compounds 4, 2 and 1 (each within the scatter of the next).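

In this assay the two halogens are not interchangeable at this position: chloro does not keep the modest gain seen with fluoro (a 2.3-fold higher number from compound 3 to compound 4 (0.36 log units; beyond the scatter)). Chloro in place of hydrogen stays within the scatter (a 1.1-fold lower number from compound 1 to compound 4 (0.04 log units; within the scatter)), as does 4-chlorophenyl in place of 2-aminophenyl (a 1.1-fold lower number from compound 2 to compound 4 (0.03 log units; within the scatter)), so among these compounds only the fluoro compound 3 stands apart. Nothing at hand explains why fluoro and chloro differ here.

On these data alone, whether bromo, methoxy or a carboxylic acid at this position would track with fluoro or with chloro remains open.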